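Swapping Nitro for Chloro: What to Expect

The compounds below may be only part of what the source reports. "The series", "measured", "known", "first", "only" and "open" are said of these compounds alone.

Compound 1 `COc1cc(C(=O)c2sc(-c3ccc(Br)cc3)cc2N)cc(OC)c1OC`: 86 nM
Compound 2 `COc1cc(C(=O)c2sc(-c3ccc([N+](=O)[O-])cc3)cc2N)cc(OC)c1OC`: 99 nM

In a functional assay on CCRF-CEM cells (Homo sapiens) for antiproliferative activity (on this read-out lower numbers stand for stronger inhibition and higher numbers for weaker inhibition), compound 2 gives 99 nM. That puts it level with compound 1 at 86 nM, since the two values lie within the usual scatter of repeated measurements.

The next compound is compound 3 `COc1cc(C(=O)c2sc(-c3ccc(Cl)cc3)cc2N)cc(OC)c1OC`, which has chloro in place of nitro on an aromatic carbon, para to a large group, so 4-nitrophenyl becomes 4-chlorophenyl: chloro in place of nitro on an aromatic carbon. The rest of the molecule stays the same.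

For the measured compounds named here, only one measured step bears on this change. It is a 1.2-fold higher number from compound 1 to compound 2 (0.06 log units; within the scatter), a swap at the same place on the molecule, and it stayed within the scatter. Going by the values given here, one step is thin evidence, and no chloro compound has been measured yet. Even so, the only exchange seen at this place gives no reason to expect a large shift, so no step beyond the scatter is expected in this assay.

The estimated change is a 1.1-fold lower number from compound 2 to compound 3 (0.04 log units; within the scatter).

For compound 3 the estimated value is 90 nM, with an expected range of 40 nM to 200 nM.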

Compound 3, half-maximal inhibitory concentration: 70 nM
Beside the measured number, compound 3's estimate is 1.3-fold (0.11 log units) above it, and the stated range covers the measured number.
By their numbers in this assay, from the lowest: compounds 3, 1 and 2 (each within the scatter of the next).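

With chloro now measured, three different groups have been tried at this place on the ring, and in this assay the swap of nitro for chloro gives a 1.4-fold lower number from compound 2 to compound 3 (0.15 log units; within the scatter) and the swap of bromo for chloro gives a 1.2-fold lower number from compound 1 to compound 3 (0.09 log units; within the scatter), so neither step stands out from the noise of the measurement. Together with the earlier bromo and nitro pair, this means compound 1, compound 2 and compound 3 cannot be told apart in this read-out. That holds even for the swap of nitro, with its three heavy atoms and two hydrogen-bond acceptors, for chloro, with one heavy atom and no hydrogen-bond acceptors, so this place has so far tolerated a real change in the group's make-up without a step beyond the scatter.

These three compounds leave open what a group of another kind would do at this place, such as an amine, a carboxylic acid or a longer chain. They also leave open whether the same level values would hold for these groups at a different place on the ring. Nothing available here explains why the three numbers sit so close together.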